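Nitro to amino swap in a diaryl ether series

The compounds below may be only part of what the source reports. "The series", "measured", "known", "first", "only" and "open" are said of these compounds alone.

Compound 1, `Nc1cc(Oc2cccc(NCc3cccc(OC(F)(F)F)c3)c2)ccc1[N+](=O)[O-]`, in a functional assay on PLC5 cells (Homo sapiens) for inhibition, read by MTT assay, with a stated time of 24 h (on this read-out higher numbers stand for weaker inhibition and lower numbers for stronger inhibition), gives 8300 nM. Compound 2, `Nc1cc(Oc2cccc(NS(=O)(=O)c3cccc(C(F)(F)F)c3)c2)ccc1[N+](=O)[O-]`, in this assay gives 3900 nM. Compound 3, `Nc1ccc(Oc2cccc(NCc3cccc(OC(F)(F)F)c3)c2)cc1N`, in this assay reaches only a limit of the assay, > 15000 nM.

Compound 1 and compound 2 share a core but differ in the larger part of the molecule; that difference between the two cores is not broken down here. Their two values show compound 2 with the lower number and compound 1 with the higher one, a gap beyond the scatter.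

One change is measured within the series: amino in place of nitro on an aromatic carbon. It gave an at least 1.8-fold higher number from compound 1 to compound 3 (0.25 log units; that floor lies within the scatter). The step is a floor because of the limit of > 15000 nM in this assay, at which 1 of the 3 values shown sits, so its true size is not known from these two compounds alone.

Compound 4, `Nc1ccc(Oc2cccc(NS(=O)(=O)c3cccc(C(F)(F)F)c3)c2)cc1N`, is not yet measured. It stands to compound 2 as compound 3 stands to compound 1: amino in place of nitro on an aromatic carbon. The place is the same word for word, so this is the same change on the other core. In this assay the step from compound 2 to compound 4 is expected to run in the same direction and to be of at least the measured size, resting on an at least 1.8-fold higher number from compound 1 to compound 3 (0.25 log units; that floor lies within the scatter); the estimate is a 3.1-fold higher number from compound 2 to compound 4 (0.49 log units; beyond the scatter). Compound 4 is therefore expected to give about 12000 nM, between 5000 nM and 30000 nM, with a real chance that only a limit is reported.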

Compound 4, half-maximal inhibitory concentration: > 15000 nM
Compound 4 was reported as a limit; the forecaster's own chance of this, stated with the estimate: 35%; middle value at least 1.2-fold (0.09 log units) from the limit.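

In this assay, amino in place of nitro on an aromatic carbon gives a higher number on both cores, and the new step reads an at least 3.8-fold higher number from compound 2 to compound 4 (0.58 log units; beyond the scatter). The direction therefore agrees across the two cores, and it is beyond the scatter only on the core of compound 2, while the sizes cannot be compared because each step is only a floor: the same change on two cores in this assay, an at least 1.8-fold higher number (0.25 log units; that floor lies within the scatter) from compound 1 to compound 3 and an at least 3.8-fold higher number (0.58 log units; beyond the scatter) from compound 2 to compound 4; the limit leaves it open whether they differ. Compound 3 and compound 4 both sit at a limit of the assay, so the 3,4-diaminophenyl compounds cannot be ranked against each other, and nothing shows whether the order seen between the two nitro compounds persists after the change: the limit of > 15000 nM in this assay, at which 2 of the 4 values shown sit.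

The compounds shown leave open how much of the step belongs to the loss of nitro and how much to the entry of amino, and whether another group in that place, such as a nitrile, a carboxylic acid or a methyl ester, would keep a number that can be read on either core. Also open, on these data alone, is which part of the difference between the two cores goes with the lower number of compound 2, since those cores differ in more than one place.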